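This account rests on a few compounds, and the source may have more. Where it says the series, first, only, none or still open, it means among the compounds named here.

Measured so far:
compound 1 `Nc1scc(CN2CCN(c3ccc(OC(F)(F)F)cc3)CC2)c1C(=O)c1ccc(Cl)cc1`: 0%
compound 2 `Nc1scc(CN2CCN(c3ccc(F)c(Cl)c3)CC2)c1C(=O)c1ccc(Cl)cc1`: 4.2%

In a functional assay on CHO cells with adenosine receptor A1 (Homo sapiens) as the target, read by cAMP accumulation and immunoassay, with a stated time of 6 min, tested at 0.01 uM (a higher number here means a weaker effect of the compound at the concentration tested, a lower number a stronger effect), compound 1 gives 0% and compound 2 gives 4.2%. Among the compounds with values here, the single step between them, a number 4.2 percentage points higher from compound 1 to compound 2 (within the scatter), does not separate the two, so compound 2 stands level with compound 1 and neither can be called the more active of the pair.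

Compound 3 `Nc1scc(CN2CCN(c3ccccc3Cl)CC2)c1C(=O)c1ccc(Cl)cc1` is the next point in the same series. Its change from compound 2: 2-chlorophenyl in place of 3-chloro-4-fluorophenyl on an amine nitrogen in a ring. Within the data shown here, the only measured step that bears on it is the exchange of the aryl group on the same ring nitrogen from compound 1 to compound 2, which stayed within the scatter. On that basis no step beyond the scatter is expected from compound 2 to compound 3: a number 1.2 percentage points lower from compound 2 to compound 3 (within the scatter). For compound 3 in this assay the expected value is 3%, with a range from -6% to 13%.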

Compound 3, a percentage reported as activity, at one concentration (the size of the read-out at that concentration, not a potency): -2.1%
Compound 3: middle estimate off by 5.1 percentage points, on the high side, within the range that was stated.
By their numbers in this assay, from the lowest: compounds 3, 1 and 2 (each within the scatter of the next).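

In this assay, within the data shown here, 2-chlorophenyl in place of 3-chloro-4-fluorophenyl on the ring nitrogen gives a number 6.3 percentage points lower from compound 2 to compound 3 (within the scatter), and 2-chlorophenyl in place of 4-(trifluoromethoxy)phenyl gives a number 2.1 percentage points lower from compound 1 to compound 3 (within the scatter), so no pair among the three compounds separates. The exchange here removes fluorine and leaves chlorine as the only atom on the phenyl ring other than carbon and hydrogen, yet this read-out at a single concentration still does not distinguish the three aryl groups. Nothing available explains why these values stand level.

Going by these compounds, all three compounds carry a halogen-bearing or trifluoromethoxy-bearing phenyl on this nitrogen, so the outcome with an unsubstituted phenyl, a benzyl group or a short alkyl chain there stays open. Also open, on these data alone, is whether these three aryl groups would separate at other concentrations.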